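The compounds below may be only part of what the source reports. "The series", "measured", "known", "first", "only" and "open" are said of these compounds alone.

Series notes. Going by the values given here, compound 1 `CCOCCn1c(N2CCN(C)CC2)nc2ccccc21` gives the lowest of the three numbers so far in a functional assay on ileum for inhibition of histamine H1 receptor (Cavia porcellus) (a higher number here means a weaker inhibitor, a lower number a stronger inhibitor), at 10 nM. Compound 2 `CCNCCn1c(N2CCN(C)CC2)nc2ccccc21` gives 290 nM in this assay, and compound 3 `CCCOCCn1c(N2CCN(C)CC2)nc2ccccc21` gives 20 nM. The step of a 29-fold higher number from compound 1 to compound 2 (1.46 log units; beyond the scatter) is large, whereas a 2.0-fold higher number from compound 1 to compound 3 (0.30 log units; within the scatter) stays within the scatter. Compound 4 `CCCN1CCN(c2nc3ccccc3n2CCOCC)CC1` is not yet measured; it differs from compound 1 by ethyl in place of hydrogen on a saturated chain carbon bound to an amine nitrogen in a ring. Among the compounds with values here, no measured step touches the amine nitrogen in a ring, so nothing directly bears on this change; the only chain extension on record, from compound 1 to compound 3, was within the scatter, which gives weak support for a small effect. A step no larger than the scatter is therefore expected, as a 2.0-fold higher number from compound 1 to compound 4 (0.30 log units; within the scatter). Compound 4 is estimated at 20 nM, range 5 nM to 80 nM.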

Compound 4, half-maximal inhibitory concentration: 16 nM
For compound 4 the middle estimate is 1.3-fold (0.10 log units) above the measured one, within the range that was stated.
By their numbers in this assay, from the lowest: compounds 1, 4 and 3 (each within the scatter of the next); then compound 2.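

Going by these compounds alone, this is the first measured change at the amine nitrogen in a ring: methyl to propyl there gives a 1.6-fold higher number from compound 1 to compound 4 (0.20 log units; within the scatter) in this assay. The place therefore accepts the added ethyl on a saturated chain carbon without a step beyond the scatter, as the ether-chain extension in compound 3 did at the other end of the molecule. Nothing at hand explains this result. Still open, from the compounds shown here alone, is whether a longer chain, a benzyl group or a carboxylic acid at this place would be accepted as well, and whether propyl would behave the same way alongside the ethylamino chain of compound 2.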